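The source may report more compounds than this note shows. Statements on the series, on what has been measured and on what is new or still open speak of the compounds shown alone.

Measured compounds:
- compound 1, `COc1cc(C)cc(-c2c(-c3ccnc(-c4ccc(C(C)=O)cc4)c3)cnn2CC#N)c1`: 3870 nM in a functional assay on MDA-MB-468 cells (Homo sapiens) for inhibition, read by sulforhodamine B assay, with a stated time of 48 h; on this read-out higher numbers stand for weaker inhibition of growth and lower numbers for stronger inhibition of growth
- compound 2, `Cc1cc(O)cc(-c2nn(CC#N)cc2-c2ccnc(-c3ccc(Oc4ccccc4)cc3)c2)c1`: 3850 nM
- compound 3, `COc1cc(C)cc(-c2nn(CC#N)cc2-c2ccnc(-c3ccc(N(C)C)cc3)c2)c1`: 635 nM

Compound 1 carries the highest number of the three in this assay. Compound 2 sits nearest to it, a gap that lies within the scatter, so the two are not distinguished. Compound 3 is furthest away, with a lower number that lies beyond the scatter; compound 3 differs from compound 1 in more than one place, so its value records only what a second substitution pattern gives, not a step.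

Compound 4, `COc1cc(C)cc(-c2c(-c3ccnc(-c4ccc(N(C)C)cc4)c3)cnn2CC#N)c1`, has not been measured. It differs from compound 1 in one place: dimethylamino in place of acetyl on an aromatic carbon. Among the compounds with values here, no measured pair in this set shows this exchange on an otherwise identical scaffold, so its size has to be estimated. Within the data shown here, the only compound bearing the dimethylamino group, compound 3, gives 635 nM, the lowest number in the set, which points toward a lower number for compound 4 as well, though with no direct step to lean on. The expectation for compound 4 is therefore a step downward of a 3.2-fold lower number from compound 1 to compound 4 (0.51 log units; beyond the scatter), and an estimated value of 1200 nM with a range from 300 nM to 4500 nM.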

Compound 4, concentration for total growth inhibition: 79.8 nM
Beside the measured number, compound 4's estimate is 15-fold (1.18 log units) above it, outside the stated range (below it).
By their numbers in this assay, from the lowest: compound 4; then compound 3; then compounds 2 and 1 (each within the scatter of the next).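

In this assay, within the data shown here, exchanging acetyl for dimethylamino on the aromatic carbon para to a large group gives a 48-fold lower number from compound 1 to compound 4 (1.69 log units; beyond the scatter), the first direct reading of a change at this position on an otherwise identical scaffold. The two groups match in heavy-atom count and in hydrogen-bond donors and acceptors, and neither has a ring or a net charge, so these counts do not separate them, and the large step cannot be read from them. The 4-acetylphenyl to 4-(dimethylamino)phenyl exchange is thus shown to matter strongly in this series, but nothing available accounts for the size of the step.

As far as these compounds go, it remains open whether the step is specific to dimethylamino or would also appear with a primary amine, methylamino, or a cyclic amine such as morpholine at the same place. A single pair also leaves open whether a methoxy or a fluorine there would fall nearer compound 1 or compound 4, and whether the exchange has the same size on the substitution pattern of compound 3.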